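Adding a piperidinylmethyl group to compound 2

This account rests on a few compounds, and the source may have more. Where it says the series, first, only, none or still open, it means among the compounds named here.

Compound 2 `Cc1csc2cc([C@H](C)Nc3ncnc(N)c3C#N)c(-c3ccccc3)c(=O)n12` gives the highest reading of three compounds in a physicochemical assay for lipophilicity (on this read-out lower numbers stand for lower lipophilicity and higher numbers for higher lipophilicity), at 2.7. Compound 1 `Cc1csc2cc([C@H](C)Nc3ncnc(N)c3C#N)c(-c3cccc(CC4CCN(C(C)C)CC4)c3)c(=O)n12` gives 1.1 in this assay, and compound 3 `Cc1csc2cc([C@H](C)Nc3ncnc(N)c3C#N)c(Cc3cccc(CN(C)C)c3)c(=O)n12` gives 0.8. Compound 4 `Cc1csc2cc([C@H](C)Nc3ncnc(N)c3C#N)c(-c3cccc(CN4CCC(N(C)C)CC4)c3)c(=O)n12` has not been measured yet; it differs from compound 2 by (4-(dimethylamino)piperidin-1-yl)methyl in place of hydrogen on an aromatic carbon. Within the data shown here, two measured steps bear on this change. Going from compound 1 to compound 2 removes a ring-bearing group with one nitrogen from the same position, and the reading rose by a number 1.60 log units higher from compound 1 to compound 2 (beyond the scatter). Going from compound 2 to compound 3 brings in a group with a nitrogen on a benzyl, and the reading fell by a number 1.90 log units lower from compound 2 to compound 3 (beyond the scatter). Compound 4 adds a group with two nitrogens, so a large step down is expected here, of about a number 1.80 log units lower from compound 2 to compound 4 (beyond the scatter). Compound 4 is therefore expected to give about 0.9 in this assay, most likely between 0.3 and 1.5.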

Compound 4, distribution coefficient: 0.5
For compound 4 the middle estimate is 0.40 log units above the measured one, and the stated range covers the measured number.
By their numbers in this assay, from the lowest: compounds 4, 3 and 1 (each within the scatter of the next, the first and the last beyond it); then compound 2.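

On the aromatic carbon meta to a large group, adding (4-(dimethylamino)piperidin-1-yl)methyl gives a step of a number 2.20 log units lower from compound 2 to compound 4 (beyond the scatter) in this assay, so this group also belongs among the large downward changes at this position. The two groups built on a piperidine ring are not interchangeable here: exchanging 1-isopropylpiperidin-4-yl for 4-(dimethylamino)piperidin-1-yl on the chain carbon gives a number 0.60 log units lower from compound 1 to compound 4 (beyond the scatter), so the make-up of the group still moves the reading once the ring is present. No measurement available here explains the difference between these two groups.

The compounds shown leave open how a morpholine ring or an open-chain amine would read at this position. They also leave open where a carboxylic acid on the same chain would fall in this assay relative to these amines.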